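The source may hold more compounds than are shown below. What is called first, only, known or untested is meant among the compounds shown, and "the series" means these compounds.

Compound 2 `CCC(CC)Nc1nc(C)nc(N(CC)c2ccc(C(C)C)cc2Br)n1` stands, in an assay on isolated protein for binding affinity to corticotropin-releasing factor receptor 1 (Homo sapiens) (a lower number here means a stronger inhibitor, a higher number a weaker inhibitor), as the higher of the two single numbers gathered so far, giving 41 nM. Within the data shown here, the nearest number belongs to compound 1 `C=CCN(c1nc(C)nc(N(CC)c2ccc(C(C)C)cc2Br)n1)C1CC1`, which in this assay gives 5 nM; the change an 8.2-fold higher number from compound 1 to compound 2 (0.91 log units; beyond the scatter) is the only measured step between compounds that differ in a single place. Compound 3 `CCN(CC)c1nc(C)nc(N(CC)c2ccc(C(C)C)cc2Br)n1`, measured twice, gives 27 nM; 27 nM (2 entries); those values and the value of compound 2 lie within the usual scatter of each other, so no order can be read from that pair. Compound 4 `CCCN(CCC)c1nc(C)nc(N(CC)c2ccc(C(C)C)cc2Br)n1` has not yet been measured. The change is dipropylamino in place of (pentan-3-yl)amino on an aromatic carbon. Among the measured compounds shown here, the one step that bears on it ran in the opposite sense, from a group without a hydrogen-bond donor to one with a donor, and raised the number; here the donor is removed again, and compound 3, whose group likewise carries no donor, shows no difference from compound 2 beyond the scatter. A step of a 1.6-fold lower number from compound 2 to compound 4 (0.21 log units; within the scatter) is therefore expected: a small move toward a lower number, if any. For compound 4 the estimate in this assay is 25 nM, with a range from 8 nM to 80 nM.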

Compound 4, inhibition constant: 4 nM
Compound 4: middle estimate off by 6.3-fold (0.80 log units), on the high side; the whole stated range lies above it.
By their numbers in this assay, from the lowest: compounds 4 and 1 (each within the scatter of the next); then compound 2.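

In this assay this position proves far more sensitive than the earlier values suggested, and dipropylamino in place of (pentan-3-yl)amino brings a 10-fold lower number from compound 2 to compound 4 (1.01 log units; beyond the scatter) as a large step. The open-chain dipropylamino group also reaches the level of allyl(cyclopropyl)amino, with only a 1.3-fold lower number from compound 1 to compound 4 (0.10 log units; within the scatter) between them, so neither a ring nor a double bond is needed in this group for a low number among these compounds. Having no hydrogen-bond donor is not enough by itself, as compound 3 also lacks one and gives 27 nM; 27 nM (2 entries) in this assay without reaching that level.

No measured evidence here explains the size of this step. The compounds shown leave open whether a longer chain such as dibutylamino, or a propyl chain ending in a hydroxyl group, would keep the number this low.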